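Taking the Hydroxy Group off Compound 2

This account rests on a few compounds, and the source may have more. Where it says the series, first, only, none or still open, it means among the compounds named here.

Compound 1 `CN(C)C(=O)c1cc2cnc(Nc3ccc(NC(=O)C4(C(=O)Nc5cccc(O)c5)CC4)cc3)nc2n1C1CCCC1` and compound 2 `CN(C)C(=O)c1cc2cnc(Nc3ccc(NC(=O)C4(C(=O)Nc5ccc(O)cc5)CC4)cc3)nc2n1C1CCCC1` share one core and differ only in where the hydroxy group sits on the phenyl ring of the amide. In a functional assay on NCI-H460 cells (Homo sapiens) for inhibition, read by CCK-8 assay, with a stated time of 72 h, tested at 1 uM (a lower number here means less inhibition of growth, a higher number more inhibition of growth at the concentration tested), compound 1 gives 75.5% while compound 2 gives 90.4% and so holds the higher of the two numbers, with a gap beyond the scatter.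

Compound 3 `CN(C)C(=O)c1cc2cnc(Nc3ccc(NC(=O)C4(C(=O)Nc5ccccc5)CC4)cc3)nc2n1C1CCCC1` carries hydrogen in place of hydroxy on an aromatic carbon, para to a large group, so that 4-hydroxyphenyl becomes phenyl (hydrogen in place of hydroxy on an aromatic carbon). Within the data shown here, only one measured step bears on this change. It is a number 14.9 percentage points higher from compound 1 to compound 2 (beyond the scatter) and it is modest. Among the measured compounds shown here, that step shifts the hydroxy group without removing it, so no measured compound shows what its absence does, and any forecast is loose. For the measured compounds named here, with that modest step as the only guide, a fall of similar size is expected rather than a collapse. The expected change is a number 14.4 percentage points lower from compound 2 to compound 3 (beyond the scatter) on this estimate. Compound 3 is therefore estimated at 76% in this assay with a range of 55% to 90% expected for it.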

Compound 3, percent growth inhibition at one concentration: 42.4%
Estimate against measurement, compound 3: 33.6 percentage points above; the measured number lies below the stated range.
By their numbers in this assay, from the lowest: compound 3; then compound 1; then compound 2.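

The hydroxy group on this phenyl ring proves far more important than the earlier pair could show: in this assay, replacing it with hydrogen gives a number 48 percentage points lower from compound 2 to compound 3 (beyond the scatter), and the same replacement starting from the other hydroxy isomer gives a number 33.1 percentage points lower from compound 1 to compound 3 (beyond the scatter). Moving the hydroxy group had produced only a number 14.9 percentage points higher from compound 1 to compound 2 (beyond the scatter), so among these compounds its presence counts for more than which of the two places it occupies, although 4-hydroxyphenyl remains the better of the two. Both hydroxyphenyl compounds stand above the plain phenyl compound, which shows that neither isomer owes its growth inhibition to the shared core and phenyl amide alone. No measurement available here explains why the loss of the hydroxy group has so large an effect.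

From the compounds shown here alone, whether another group on the same aromatic carbon, such as methoxy, an amine, fluorine or a carboxylic acid, could hold the number near that of compound 2 remains open. Also open is whether the order of these compounds would persist across a range of concentrations or in other cell lines.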